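Oxetan-2-yl for 1,4-dioxan-2-yl: expected clearance of compound 3

The compounds below may be only part of what the source reports. "The series", "measured", "known", "first", "only" and "open" are said of these compounds alone.

Measured so far in an in vitro ADME assay on microsomes from liver (Homo sapiens) for metabolic stability, read by HPLC (on this read-out higher numbers stand for fast clearance and lower numbers for slow clearance), for this series
- compound 1 `NC(=O)[C@@H](CCC(F)(F)F)N(CC1COC1)S(=O)(=O)c1ccc(Cl)cc1` gives 16.9 mL/min/kg
- compound 2 `NC(=O)[C@@H](CCC(F)(F)F)N(C[C@H]1COCCO1)S(=O)(=O)c1ccc(Cl)cc1` gives 176 mL/min/kg

Within the data shown here, compound 2 holds the higher of the two numbers, with compound 1 as its only and nearest neighbour. Compound 3 `NC(=O)[C@@H](CCC(F)(F)F)N(C[C@H]1CCO1)S(=O)(=O)c1ccc(Cl)cc1` follows from compound 2 by the change oxetan-2-yl in place of 1,4-dioxan-2-yl on a saturated chain carbon bound to a sulfonamide nitrogen on a saturated chain carbon bound to a sulfonamide nitrogen. Among the measured compounds shown here, one measured step bears on this: a 10-fold higher number from compound 1 to compound 2 (1.02 log units; beyond the scatter), large and beyond the scatter, with 1,4-dioxan-2-yl in place of oxetan-3-yl. Compound 3 loses the same 1,4-dioxan-2-yl, but it carries oxetan-2-yl rather than oxetan-3-yl, so that step is expected to carry over only in part. In this assay a large step towards slower clearance is still expected, estimated as a 4.4-fold lower number from compound 2 to compound 3 (0.64 log units; beyond the scatter) and beyond the scatter. Compound 3 is estimated at 40 mL/min/kg as a middle value (15 mL/min/kg to 110 mL/min/kg).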

Compound 3, clearance: 63.8 mL/min/kg
Estimate against measurement, compound 3: 1.6-fold (0.20 log units) below; the range from low to high includes it.
By their numbers in this assay, from the lowest: compound 1; then compound 3; then compound 2.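

In this assay, on a saturated chain carbon bound to a sulfonamide nitrogen, oxetan-2-yl in place of 1,4-dioxan-2-yl gives a 2.8-fold lower number from compound 2 to compound 3 (0.44 log units; beyond the scatter), so moving from the six-membered to a four-membered ring here does not by itself recover the low number of compound 1. The two oxetanes also part, with a 3.8-fold higher number from compound 1 to compound 3 (0.58 log units; beyond the scatter) for oxetan-2-yl in place of oxetan-3-yl, which shows that at this position the point of attachment of the ring counts as well as its size. No data at hand explain either step.

Whether tetrahydrofuran-2-yl, with its five-membered ring, would fall among these numbers stays open. So does the effect of the opposite configuration at the defined ring stereocentre of the oxetan-2-yl group, or of a morpholin-2-yl group carrying an amine in the ring.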